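Benzylamide aryl variation in a pyridinyl ether series

The compounds below may be only part of what the source reports. "The series", "measured", "known", "first", "only" and "open" are said of these compounds alone.

Compound 3 `COc1cc(CNC(=O)c2cccc(C(C)Oc3ccnc(Nc4cnn(C)c4)c3)c2)cc(OC)c1OC` carries a 3,4,5-trimethoxyphenyl on a saturated chain carbon bound to an amide-type nitrogen. In a functional assay on NCI-H3122 cells (Homo sapiens) for antiproliferative activity, read by MTT assay, with a stated time of 48 h (a lower number here means a stronger inhibitor, a higher number a weaker inhibitor), compound 3 gives 29000 nM, the highest of the two numbers shown, with compound 1 `Cc1ccc(CNC(=O)c2cccc(C(C)Oc3cccnc3Nc3nncs3)c2)cc1` nearest at 20800 nM, a gap that lies within the scatter. Compound 2 `COc1cccc(CNC(=O)c2cccc(C(C)Oc3ccnc(Nc4cnn(C)c4)c3)c2)c1` reports only a limit in this assay, > 100000 nM. Among the compounds with values here, the one measured step at the same carbon, an at least 3.4-fold lower number from compound 2 to compound 3 (0.53 log units; beyond the scatter), is at least modest, and its true size is bounded by the limit of > 100000 nM in this assay, at which 1 of the 3 values shown sits.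

Compound 4 `CC(Oc1ccnc(Nc2cnn(C)c2)c1)c1cccc(C(=O)NCc2ccc(C#N)cc2)c1` differs from compound 3 by 4-cyanophenyl in place of 3,4,5-trimethoxyphenyl on a saturated chain carbon bound to an amide-type nitrogen. The step from compound 2 to compound 3 shows that the aryl group at this position can move the number beyond the scatter, but a single step in one direction gives no direction for a 4-cyanophenyl. The expected step is therefore a 1.2-fold higher number from compound 3 to compound 4 (0.08 log units; within the scatter), close to none beyond the scatter, with the uncertainty widened toward weaker inhibition. Compound 4 is estimated at 35000 nM, between 9000 nM and 100000 nM.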

Compound 4, half-maximal inhibitory concentration: 35100 nM
The estimate for compound 4 lay 1.0-fold (0.00 log units) below the measured number; low and high end bracket the measured number.
By their numbers in this assay, from the lowest: compounds 1, 3 and 4 (each within the scatter of the next). At a limit, above all of these: compound 2.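

In this assay, 4-cyanophenyl in place of 3,4,5-trimethoxyphenyl gives a 1.2-fold higher number from compound 3 to compound 4 (0.08 log units; within the scatter), so two aryl groups that differ in heavy atoms and hydrogen-bond acceptors read alike at this position. 4-Cyanophenyl in place of 3-methoxyphenyl gives an at least 2.8-fold lower number from compound 2 to compound 4 (0.45 log units; beyond the scatter), a second step beyond the scatter in the same direction as the step to compound 3, so compound 2 now stands apart from two aryl groups rather than one. The size of that step remains bounded, as compound 2 reports only a limit: the limit of > 100000 nM in this assay, at which 1 of the 4 values shown sits.

The data do not explain why 3-methoxyphenyl stands apart from 4-cyanophenyl and 3,4,5-trimethoxyphenyl. On these data alone, it also remains open whether an amine or a carboxylic acid on this aryl ring, or a longer chain at this place, would move the number beyond the scatter of compound 3 and compound 4.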